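Allyl Capping of the Phenol in a Pyridyl Ketone Series

The source may hold more compounds than are shown below. What is called first, only, known or untested is meant among the compounds shown, and "the series" means these compounds.

Measured so far: compound 1 `O=C(c1cccnc1)c1ccccc1O` gives 33400 nM; compound 2 `Cc1ccc(O)c(C(=O)c2cccnc2)c1` gives 10000 nM.

Among the measured compounds shown here, in a functional assay on PC-3 cells (Homo sapiens) for cytotoxicity, read by sulforhodamine B assay, with a stated time of 48 h (on this read-out lower numbers stand for stronger inhibition and higher numbers for weaker inhibition), compound 1 stands highest of the two numbers, with a 3.3-fold lower number from compound 1 to compound 2 (0.52 log units; beyond the scatter) as the only step measured. Compound 3 `C=CCOc1ccccc1C(=O)c1cccnc1` differs from compound 1 by allyl in place of hydrogen on an oxygen on an aromatic ring. For the measured compounds named here, no measured step touches this oxygen, so the one step known, which concerns methyl on an aromatic carbon, gives little guidance. With nothing to steer the direction, the number for compound 3 is expected to stay near that of compound 1, so a step of a 1.1-fold lower number from compound 1 to compound 3 (0.05 log units; within the scatter) is expected. Compound 3 is thus estimated at 30000 nM, within 8000 nM to 100000 nM.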

Compound 3, half-maximal inhibitory concentration: 55000 nM
Compound 3: the middle estimate sits 1.8-fold (0.26 log units) below what was measured; measured number inside the range.
By their numbers in this assay, from the lowest: compound 2; then compounds 1 and 3 (each within the scatter of the next).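

In this assay the first step shown at this oxygen, hydroxy to allyloxy, reads a 1.6-fold higher number from compound 1 to compound 3 (0.22 log units; within the scatter) and so gives a first view of this position. Compound 1 and compound 3 cannot be told apart here, so in this pair, capping the oxygen with allyl leaves the number within the scatter. No measured evidence explains this result. Still open, on these data alone, is whether a longer chain or a chain ending in an amine on this oxygen would also stay within the scatter of compound 1.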